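Working notes: amide variation on the triazole series, A3 displacement

A few compounds are considered here, and "the series" means these few. Any claim that something is new, unique, unknown or untested is made for them only; others in the source may bear on it.

Measured compounds in an assay on CHO cells for displacement of a labelled ligand from adenosine receptor A3 (Homo sapiens), tested at 1 uM; on this read-out lower numbers stand for less inhibition and higher numbers for more inhibition at the one concentration tested (going by the name of the read-out):
- compound 1 `C#CCOC(=O)Nc1ccc(C)cc1-n1cnc(-c2ccc(OC)cc2)n1`: 35%
- compound 2 `COc1ccc(-c2ncn(-c3cc(C)ccc3NC(=O)OCc3ccccc3)n2)cc1`: 47%
- compound 3 `COc1ccc(-c2nc(N(C(C)=O)C(C)=O)n(-c3ccccc3)n2)cc1`: 19%

Compound 3 stands lowest of the three numbers; the nearest is compound 1, and the furthest is compound 2, both beyond the scatter. Among the compounds with values here, the only single-place step measured so far is a number 12 percentage points higher from compound 1 to compound 2 (beyond the scatter), a modest change at the carbamate chain and not at the position changed here.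

Compound 4 `COc1ccc(-c2nc(NC(=O)c3ccccc3)n(-c3ccccc3)n2)cc1` has not been measured. The change from compound 3 is benzamido in place of diacetylamino on an aromatic carbon. Within the data shown here, no measured step bears directly on this change; the one step known concerns another part of the molecule, so no size of step can be borrowed from it. The replacement is of moderate size and keeps an acyl nitrogen on the same aromatic carbon, so a step within the scatter, or at most a modest one, is expected in this assay.

For compound 4 the expected value in this assay is 30%, within 10% to 55%, which would mean an expected step of a number 11 percentage points higher from compound 3 to compound 4 (beyond the scatter).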

Compound 4, a percentage reported as inhibition, at one concentration (the size of the read-out at that concentration, not a potency): 50%
Estimate against measurement, compound 4: 20 percentage points below; the range from low to high includes it.
By their numbers in this assay, from the lowest: compound 3; then compound 1; then compounds 2 and 4 (each within the scatter of the next).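

In this assay, within the data shown here, benzamido in place of diacetylamino on the aromatic carbon between two ring nitrogen atoms gives a number 31 percentage points higher from compound 3 to compound 4 (beyond the scatter), the first step read at this position, since the only earlier step lay on the carbamate chain. Keeping an acyl nitrogen on this carbon therefore does not hold the number steady, and the position responds strongly to which acyl nitrogen group it carries. No available evidence accounts for the size of this step.

The step brings in a six-membered aromatic ring and the amide hydrogen together, so the two cannot be separated from these compounds alone. Open, going by these compounds, is whether acetamido, which keeps the amide hydrogen without the aromatic ring, or a plain amine on this carbon would stay near compound 4 or fall towards compound 3.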